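The source may report more compounds than this note shows. Statements on the series, on what has been measured and on what is new or still open speak of the compounds shown alone.

Of the compounds shown here, three have so far been tested in a functional assay on BE(2)-C cells (Homo sapiens) for inhibition, read by MTT assay, with a stated time of 72 h; a higher number here means a weaker inhibitor of growth, a lower number a stronger inhibitor of growth. Compound 1, `N#C/C(=C\c1c[nH]c2ccccc12)C(=O)c1c[nH]c2ccccc12`, gives 12000 nM in this assay. Compound 2, `COc1ccc(CNC(=O)/C(C#N)=C/c2ccc(Br)o2)cc1`, gives 13000 nM in this assay. Compound 3, `COc1ccc(CNC(=O)/C(C#N)=C/c2ccc3ccccc3c2)cc1`, gives 42000 nM in this assay, the highest of the three numbers: its gap to compound 2, the nearest, lies beyond the usual scatter, and so does the somewhat wider gap to compound 1. Among these three, compound 3 is therefore the weakest inhibitor of growth.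

Compound 4, `N#C/C(=C\c1ccc2ccccc2c1)C(=O)NCc1ccc(Cl)c(Cl)c1`, has not yet been measured. It differs from compound 3 in one place only: 3,4-dichlorophenyl in place of 4-methoxyphenyl on a saturated chain carbon bound to an amide-type nitrogen. For the measured compounds named here, no pair of measured compounds shows this exchange, so there is no measured step to lean on, and the expectation rests on the general picture that all three measured values sit in a narrow, weak band. A step of modest size is expected from compound 3 to compound 4, more likely toward a lower number than a higher one, but not clearly beyond the scatter; the estimated step is a 1.7-fold lower number from compound 3 to compound 4 (0.23 log units; within the scatter). Compound 4 is expected to give about 25000 nM in this assay, with a likely range from 8000 nM to 70000 nM.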

Compound 4, concentration for 50% growth inhibition: 40000 nM
Compound 4: the middle estimate sits 1.6-fold (0.20 log units) below what was measured; the measured number falls inside the stated range.
By their numbers in this assay, from the lowest: compounds 1 and 2 (each within the scatter of the next); then compounds 4 and 3 (each within the scatter of the next).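

For the compounds shown here, this is the first direct test of a change on a saturated chain carbon bound to an amide-type nitrogen, and in this assay placing 3,4-dichlorophenyl where 4-methoxyphenyl stood gives a 1.1-fold lower number from compound 3 to compound 4 (0.02 log units; within the scatter), a step within the usual scatter. The two groups differ in their atoms, with chlorine entering, oxygen leaving and a hydrogen-bond acceptor lost, yet this pair shows no measurable difference in growth inhibition, so on this core the assay does not tell these two aromatic groups apart. Nothing available explains why the exchange leaves the reading flat.

This single pair cannot show whether a different kind of group at the same place, such as an amine or a carboxylic acid, would move the number beyond the scatter, or whether a longer chain in place of the saturated chain carbon would do so. It also leaves open whether the same exchange would give an equally small step on the core of compound 2, which carries the 4-methoxyphenyl group too.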